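A few compounds are considered here, and "the series" means these few. Any claim that something is new, unique, unknown or untested is made for them only; others in the source may bear on it.

Compound 1 `COc1ccc(/C=C\C(=O)O)c(OCc2cn(-c3ccc(NC(C)=O)cc3)nn2)c1CC=C(C)C`: 45700 nM
Compound 2 `COc1ccccc1-n1cc(COc2c(/C=C\C(=O)O)ccc(OC)c2CC=C(C)C)nn1`: 41500 nM
Compound 3 `COc1ccc(/C=C\C(=O)O)c(OCc2cn(-c3ccccc3)nn2)c1CC=C(C)C`: 29200 nM

These three compounds share a core and differ only at the phenyl group. In a functional assay on NCI-H322 cells (Homo sapiens) for cytotoxicity, read by MTT assay, with a stated time of 24 h (a higher number here means a weaker inhibitor, a lower number a stronger inhibitor), compound 3 gives 29200 nM, and it cannot be separated from the other two. The data show a 1.6-fold lower number from compound 1 to compound 3 (0.19 log units; within the scatter) and a 1.4-fold lower number from compound 2 to compound 3 (0.15 log units; within the scatter), and the remaining pair shows a 1.1-fold lower number from compound 1 to compound 2 (0.04 log units; within the scatter).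

Compound 4 `COc1ccc(/C=C\C(=O)O)c(OCc2cn(-c3ccccc3I)nn2)c1CC=C(C)C` differs from compound 3 by a single change: iodo in place of hydrogen on an aromatic carbon. This is iodo in place of hydrogen on an aromatic carbon, ortho to a large group. Among the measured compounds shown here, no iodo compound has been measured, so the evidence is indirect. Compound 2, with its 2-methoxyphenyl, is the closest comparison, and its step is a 1.4-fold lower number from compound 2 to compound 3 (0.15 log units; within the scatter). Compound 1, with its 4-acetamidophenyl, offers a more distant comparison, with a 1.6-fold lower number from compound 1 to compound 3 (0.19 log units; within the scatter). Neither substituent moves the number beyond the scatter, so no step beyond the scatter is expected in this assay for this change, and no firm direction can be given. The expected step is a 1.2-fold higher number from compound 3 to compound 4 (0.08 log units; within the scatter). For compound 4 the estimated value is 35000 nM, with an expected range from 17000 nM to 70000 nM.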

Compound 4, half-maximal inhibitory concentration: 42300 nM
Compound 4: the middle estimate sits 1.2-fold (0.08 log units) below what was measured; measured number inside the range.
By their numbers in this assay, from the lowest: compounds 3, 2, 4 and 1 (each within the scatter of the next).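

In this assay, among the compounds shown here, iodo in place of hydrogen on an aromatic carbon, ortho to a large group, gives a 1.4-fold higher number from compound 3 to compound 4 (0.16 log units; within the scatter) and so adds the first iodo compound to the series without separating it from the unsubstituted phenyl of compound 3. For the compounds shown here, the comparison at this same place shows that exchanging the methoxy group for iodo gives a 1.0-fold higher number from compound 2 to compound 4 (0.01 log units; within the scatter) and leaves the two compounds indistinguishable, something the earlier steps, which held no iodo compound, could not show. Replacing the whole 4-acetamidophenyl with 2-iodophenyl on the aromatic nitrogen gives a 1.1-fold lower number from compound 1 to compound 4 (0.03 log units; within the scatter) as well, so all four compounds now lie within the scatter of one another and none of the phenyl changes shown sets any compound apart.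

The compounds shown leave open whether a different group at this place, such as an amine, a carboxylic acid or a longer chain, or fluoro, chloro or bromo in place of iodo, would produce a step beyond the scatter, and whether iodo would behave the same elsewhere on the phenyl ring. Nothing available gives a reason for the closeness of these four numbers.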